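This account rests on a few compounds, and the source may have more. Where it says the series, first, only, none or still open, it means among the compounds named here.

Measured compounds:
compound 1 `COc1ccc(-n2c(COC3CCOCC3)nnc2N2C[C@@H]3C[C@]3(c3ccc(F)cc3Cl)C2)cn1`: 826 nM
compound 2 `COc1ccc(-n2c(CO[C@H]3CCOC3)nnc2N2C[C@@H]3C[C@]3(c3ccc(F)cc3Cl)C2)cn1`: 184 nM

Going by the values given here, in a functional assay on HEK293 cells for antagonist activity at Oxytocin receptor (Homo sapiens), read by calcium flux, with a stated time of 10 min, in the presence of a further agent that is not named here (a higher number here means a weaker inhibitor, a lower number a stronger inhibitor), compound 2 stands with the lowest number of the two measured, below compound 1 by a 4.5-fold lower number from compound 1 to compound 2 (0.65 log units; beyond the scatter), and that single step is the only measured change in the set.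

Compound 3 `COc1ccc(-n2c(CO[C@@H]3CCOC3)nnc2N2C[C@@H]3C[C@]3(c3ccc(F)cc3Cl)C2)cn1` is the next member. Its difference from compound 2 is the two compounds have the same atoms and bonds and differ only in configuration as drawn: 1 of 3 stereo elements differ; a stereocentre at a saturated ring carbon is drawn S in compound 2 and R in compound 3; the ring itself, its oxygen linkage and everything else in the molecule remain as in compound 2. Among the compounds with values here, no measured step bears on an inversion of this centre: the step from compound 1 to compound 2 swaps one ring for another and says nothing about how the two configurations of the oxolan-3-yl group compare. The step to compound 3 in this assay is therefore open in size and direction, and the expectation can only be anchored on compound 2, with a margin wide enough to allow a change beyond the scatter either way.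

For compound 3 the estimate in this assay is 400 nM, with a likely range from 120 nM to 1500 nM. This estimate means an expected step of a 2.2-fold higher number from compound 2 to compound 3 (0.34 log units; beyond the scatter).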

Compound 3, half-maximal inhibitory concentration: 223 nM
For compound 3 the middle estimate is 1.8-fold (0.25 log units) above the measured one; measured number inside the range.
By their numbers in this assay, from the lowest: compounds 2 and 3 (each within the scatter of the next); then compound 1.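

In this assay, inverting the stereocentre at the saturated ring carbon of the oxolan-3-yl group gives a 1.2-fold higher number from compound 2 to compound 3 (0.08 log units; within the scatter), so this centre shows no preference for either configuration as drawn in this pair. The difference from the oxan-4-yl group, seen until now with the S configuration only, also holds with the R configuration: a 3.7-fold lower number from compound 1 to compound 3 (0.57 log units; beyond the scatter). The ring change therefore does not depend on one drawn form of the oxolan-3-yl group, and the comparison of the two forms rests on a single structural difference: the fact that compounds 2 and 3 differ only in the configuration as drawn

Only two oxygen-containing rings appear on this linkage, so the compounds shown do not tell whether the ring oxygen itself matters; a cyclopentyl group or an open 2-methoxyethyl chain in the same place would separate the role of the ring oxygen from that of ring size. On these data alone, the other two stereo elements are the same in all three compounds, so the effect of inverting them on the shared core remains open.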